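Swapping cyclopropyl for 3,4-dimethylphenyl: what to expect

This account rests on a few compounds, and the source may have more. Where it says the series, first, only, none or still open, it means among the compounds named here.

Compound 1, `CCCCCCCN1CCC(C(=O)Nc2cc(Cl)c(N)cc2OC)CC1`, gives in a functional assay on the whole organism for antagonist activity, with Mus musculus as the target (on this read-out higher numbers stand for an effect only at larger amounts of compound and lower numbers for an effect already at smaller amounts), only a limit of > 10 mg/kg.
Compound 2, `COc1cc(N)c(Cl)cc1NC(=O)C1CCN(CC2CC2)CC1`, gives in this assay only a limit of > 10 mg/kg.
Compound 3, `COc1cc(N)c(Cl)cc1NC(=O)C1CCN(Cc2cccc(C#N)c2)CC1`, gives in this assay only a limit of > 4 mg/kg.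

Compound 2 therefore stands not at a number but at a limit of the assay. That limit is shared: the limit of > 10 mg/kg in this assay, at which 2 of the 3 values shown sit. The remaining value is a limit as well: the limit of > 4 mg/kg in this assay, at which 1 of the 3 values shown sits. The change considered here is 3,4-dimethylphenyl in place of cyclopropyl on a saturated chain carbon bound to an amine nitrogen in a ring, which yields compound 4, `COc1cc(N)c(Cl)cc1NC(=O)C1CCN(Cc2ccc(C)c(C)c2)CC1`.

Among the measured compounds shown here, three measured steps touch the same place on the ring amine. The closest in kind, an aromatic ring entering for cyclopropyl, is a step that the two limits leave unreadable from compound 2 to compound 3. The others are a step that the two limits leave unreadable from compound 1 to compound 2 and a step that the two limits leave unreadable from compound 1 to compound 3. None of them can be read as a size or a direction, so no step beyond the scatter can be foreseen, and the most probable outcome for compound 4 is once more a limit rather than a number.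

Compound 4 is estimated at about 10 mg/kg, within a range from 3 mg/kg to 30 mg/kg. The step this estimate implies is expected to be a number no higher from compound 2 to compound 4 (the limit leaves the size open).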

Compound 4, dose for half-maximal effect: > 8 mg/kg
Compound 4: a limit, no number; the forecaster's own chance of this, stated with the estimate: 75%; the middle value is on the limit's open side.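

Compound 4 gives only a limit, > 8 mg/kg, not a number. Its steps from compound 1, compound 2 and compound 3 therefore cannot be read in size or direction. The compounds shown leave open how far the group on the ring amine matters in this assay, since none of the four has a number.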